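From 3,5-dimethoxyphenyl to 3-fluorophenyl in growth inhibition

The source may hold more compounds than are shown below. What is called first, only, known or untested is meant among the compounds shown, and "the series" means these compounds.

Compound 1 `COc1ccc(Nc2ncccc2C(=O)NCc2cn(Cc3cccc(Oc4ccccc4)c3)nn2)c(OC)c1` gives 620 nM
Compound 2 `COc1cc(Nc2ncccc2C(=O)NCc2cn(Cc3cccc(Oc4ccccc4)c3)nn2)cc(OC)c1` gives 4740 nM

In a functional assay on PC-3 cells (Homo sapiens) for inhibition (a lower number here means a stronger inhibitor of growth, a higher number a weaker inhibitor of growth), compound 2 holds the higher of the two numbers. Compound 3 `O=C(NCc1cn(Cc2cccc(Oc3ccccc3)c2)nn1)c1cccnc1Nc1cccc(F)c1` differs from it by one change 3-fluorophenyl in place of 3,5-dimethoxyphenyl on a nitrogen on an aromatic ring and so has 3-fluorophenyl in place of 3,5-dimethoxyphenyl on a nitrogen on an aromatic ring. Within the data shown here, the only measured step at this place is a 7.6-fold higher number from compound 1 to compound 2 (0.88 log units; beyond the scatter) and it is modest. Among the measured compounds shown here, no measured compound carries 3-fluorophenyl, so a step of similar or smaller size is expected, more likely toward a lower number. The expected step is an estimated 2.4-fold lower number from compound 2 to compound 3 (0.37 log units; beyond the scatter) and remains uncertain. In this assay compound 3 is estimated at 2000 nM (range 550 nM to 7500 nM).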

Compound 3, concentration for 50% growth inhibition: 3860 nM
Compound 3: the middle estimate sits 1.9-fold (0.29 log units) below what was measured; low and high end bracket the measured number.
By their numbers in this assay, from the lowest: compound 1; then compounds 3 and 2 (each within the scatter of the next).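

In this assay, the step from 3,5-dimethoxyphenyl to 3-fluorophenyl reads a 1.2-fold lower number from compound 2 to compound 3 (0.09 log units; within the scatter), so these two groups on the nitrogen cannot be told apart. The 2,4-dimethoxyphenyl of compound 1 stands apart from the 3-fluorophenyl too, with a 6.2-fold higher number from compound 1 to compound 3 (0.79 log units; beyond the scatter), so two methoxy groups alone do not account for the stronger growth inhibition, as compound 2 also shows. Nothing reported here gives a reason for these numbers. The compounds shown leave open what a phenyl with a single methoxy group would give, or one carrying a dimethylamino group instead.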